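Replacing a methoxy with hydrogen on compound 2

The source may report more compounds than this note shows. Statements on the series, on what has been measured and on what is new or still open speak of the compounds shown alone.

compound 1 `COc1ccc(/C=C/c2cc(C)no2)cc1OC`: 63200 nM
compound 2 `COc1ccc(/C=C/C(=O)CC(C)=O)cc1OC`: 8200 nM

In an ADME assay on HEK293 cells (Homo sapiens) for cytotoxicity, read by MTT assay, with a stated time of 72 h (a higher number here means a weaker inhibitor, a lower number a stronger inhibitor), compound 2 has the lower number of these two compounds, and so stands lowest so far. The next compound is compound 3 `COc1ccc(/C=C/C(=O)CC(C)=O)cc1`, not yet measured. Its change from compound 2 is hydrogen in place of methoxy on an aromatic carbon, ortho to a methoxy group. For the measured compounds named here, the only measured step, a 7.7-fold lower number from compound 1 to compound 2 (0.89 log units; beyond the scatter), concerns a different part of the molecule. It shows that the number can move, but it says nothing direct about this methoxy. Going by the values given here, with no measured step at this place, no direction can be argued, so a change no larger than the scatter is expected, with a wide margin. Compound 3 is estimated at 10000 nM (range 3500 nM to 30000 nM) in the same test. This estimate means an expected 1.2-fold higher number from compound 2 to compound 3 (0.09 log units; within the scatter) in this assay, a step that could still fall either way.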

Compound 3, half-maximal inhibitory concentration: 18700 nM
Compound 3: the middle estimate sits 1.9-fold (0.27 log units) below what was measured; the range from low to high includes it.
By their numbers in this assay, from the lowest: compound 2; then compound 3; then compound 1.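

In this assay, for the compounds shown here, this is the first measured change on the aromatic ring itself. The earlier step concerned the other end of the molecule. Taking away the methoxy that sits ortho to a methoxy group and leaving hydrogen gives a 2.3-fold higher number from compound 2 to compound 3 (0.36 log units; beyond the scatter), a modest change in the direction of a weaker inhibitor. This position therefore does affect the number, and within this pair the methoxy goes with the lower value. Nothing measured here explains why the number moves.

The compounds shown leave open how a hydroxyl, a chlorine or an ethoxy on this same carbon would compare with methoxy and hydrogen. They also leave open whether replacing the remaining methoxy with hydrogen would shift the number in the same direction.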